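Methyl on the chain oxygen: expected effect on cytotoxicity

The compounds below may be only part of what the source reports. "The series", "measured", "known", "first", "only" and "open" are said of these compounds alone.

Compound 1 `COc1cc(/C=C/C2=CC(=O)CC(c3ccc(O)c(OC)c3)N2CCCO)ccc1O` and compound 2 `COc1cc(/C=C/C(=O)/C=C(/C=C/c2ccc(O)c(OC)c2)NCCCO)ccc1O` carry the shared core with the same chain attached in two different ways. In a functional assay on HepG2 cells (Homo sapiens) for cytotoxicity, read by MTT assay, with a stated time of 48 h (on this read-out lower numbers stand for stronger inhibition and higher numbers for weaker inhibition), compound 1 gives only a limit of the assay, > 100000 nM. Compound 2 likewise gives only a limit in this assay, > 100000 nM. Both values sit at the limit of > 100000 nM in this assay, at which 2 of the 2 values shown sit, so compound 2 cannot be ranked against compound 1 beyond noting that both stand at the limit. Compound 3 `COCCCNC(=C\C(=O)/C=C/c1ccc(O)c(OC)c1)/C=C/c1ccc(O)c(OC)c1` is to be measured in this assay; it differs from compound 2 by methyl in place of hydrogen on an oxygen on a saturated carbon. Going by the values given here, no step between measured compounds exists in this set, so the size of such a change cannot be read from the series. Because compound 2 sits at the limit of > 100000 nM in this assay, at which 2 of the 2 values shown sit, the expectation for this step is none beyond the scatter: a number no higher from compound 2 to compound 3 (the limit leaves the size open). Compound 3 is expected near 100000 nM, within 50000 nM to 200000 nM, and is likely to be reported again as a limit.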

Compound 3, half-maximal inhibitory concentration: > 100000 nM
Compound 3: only a limit was reported (the forecaster's own chance of this, stated with the estimate: 80%); the middle value sits exactly at the limit.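

Going by these compounds alone, compound 2 and compound 3 both stand at the limit in this assay, so no step from one to the other can be read: the limit of > 100000 nM in this assay, at which 3 of the 3 values shown sit. The compounds shown leave open whether methyl in place of hydrogen on an oxygen on a saturated carbon alters cytotoxicity at all.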